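Thiophene for pyridine on a hydroxyphenyl pyridine scaffold

The source may report more compounds than this note shows. Statements on the series, on what has been measured and on what is new or still open speak of the compounds shown alone.

Of the compounds shown here, two sharing one core have been tested in an assay on isolated protein for inhibition of DNA topoisomerase 1 (Homo sapiens), with a stated time of 30 min, tested at 100 uM; a higher number here means a stronger effect of the compound at the concentration tested, a lower number a weaker effect. Compound 1 `Oc1ccc(-c2cc(-c3cccc(Cl)c3)nc(-c3cccs3)c2)cc1` gives 52.4%, while compound 2 `Oc1cccc(-c2cc(-c3cccc(Cl)c3)nc(-c3ccccn3)c2)c1` gives 0.4%, the lowest of the two numbers and a gap beyond the usual scatter. Compound 3 `Oc1cccc(-c2cc(-c3cccc(Cl)c3)nc(-c3cccs3)c2)c1` differs from compound 2 in one place: thiophen-2-yl in place of pyridin-2-yl on an aromatic carbon. Since compound 1, which also carries thiophen-2-yl, gives 52.4%, the step of a number 34.6 percentage points higher from compound 2 to compound 3 (beyond the scatter) is expected to be an increase beyond the scatter. Compound 3 is estimated to give 35%, within a range from 5% to 65%.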

Compound 3, a percentage reported as inhibition, at one concentration (the size of the read-out at that concentration, not a potency): 7.6%
Compound 3: the middle estimate sits 27.4 percentage points above what was measured, within the range that was stated.
By their numbers in this assay, from the lowest: compounds 2 and 3 (each within the scatter of the next); then compound 1.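

In this assay, thiophen-2-yl in place of pyridin-2-yl alongside the 3-hydroxyphenyl group gives a number 7.2 percentage points higher from compound 2 to compound 3 (within the scatter), so this exchange does not separate the two compounds. The change that does separate compounds is 3-hydroxyphenyl in place of 4-hydroxyphenyl, with a number 44.8 percentage points lower from compound 1 to compound 3 (beyond the scatter). Nothing at hand accounts for either step. The compounds shown leave open whether pyridin-2-yl would match thiophen-2-yl alongside 4-hydroxyphenyl, and whether a methoxy group or an amine in place of the hydroxyl of compound 1 would hold its read-out.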